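The source may hold more compounds than are shown below. What is called first, only, known or untested is meant among the compounds shown, and "the series" means these compounds.

Of the compounds shown here, two built on the same core have been measured so far: compound 1, `CCCC(=O)c1ccc2c(c1)sc(=O)n2CCCCN1CCCCCC1`, and compound 2, `CCCc1ccc2c(c1)sc(=O)n2CCCN1CCCCCC1`. In an assay on cell membranes for displacement of a labelled ligand from Sigma non-opioid intracellular receptor 1 (Rattus norvegicus) (a lower number here means a stronger inhibitor, a higher number a weaker inhibitor), compound 1 gives 4.8 nM. In this assay compound 2 gives 1.4 nM, the lower of the two numbers, and its gap to compound 1 is wider than the ordinary scatter of repeated measurements, so compound 2 is the stronger inhibitor of the pair.

Compound 3, `CCCc1ccc2c(c1)sc(=O)n2CCCCN1CCCCCC1`, has not yet been measured. It differs from compound 2 in a single way: (azepan-1-yl)methyl in place of azepan-1-yl on a saturated chain carbon, three bonds along the chain from an aromatic nitrogen. In plain terms, the chain that joins the aromatic nitrogen to the azepane ring becomes longer, and nothing else changes. Among the measured compounds shown here, no measured pair differs in only this respect, so no directly comparable step exists. Compound 1 carries the longer chain but also a different group on the aromatic ring, so it cannot separate the two effects.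

Compound 3 is therefore expected to stay close to compound 2, with a modest weakening or none beyond the scatter. The expected step is a 1.8-fold higher number from compound 2 to compound 3 (0.25 log units; within the scatter). The estimate for compound 3 is 2.5 nM, within a range from 0.8 nM to 8 nM.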

Compound 3, inhibition constant: 6.1 nM
For compound 3 the middle estimate is 2.4-fold (0.39 log units) below the measured one; measured number inside the range.
By their numbers in this assay, from the lowest: compound 2; then compounds 1 and 3 (each within the scatter of the next).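

Lengthening the chain, with (azepan-1-yl)methyl in place of azepan-1-yl on a saturated chain carbon, gives a 4.4-fold higher number from compound 2 to compound 3 (0.64 log units; beyond the scatter) in this assay. Among the compounds shown here, this is the first direct sign that binding at this position depends on chain length: with everything else held the same, the compound with the shorter chain is the stronger inhibitor, though compound 3 still binds in the low nanomolar range. With the longer chain held fixed, propyl in place of propylcarbonyl on an aromatic carbon gives a 1.3-fold higher number from compound 1 to compound 3 (0.10 log units; within the scatter), so these two ring groups cannot be told apart at this chain length, and no measurement shown explains the effect of the chain.

As far as these compounds go, two points of a single step do not show a trend, so it remains open whether a still longer chain would continue this weakening or whether the effect stops at compound 3. From the compounds shown here alone, it is also open whether propylcarbonyl would match propyl on the shorter chain of compound 2, since the two groups have been compared only on the longer chain.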